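Pyrazolone amides with a thienopyrimidine ether: aryl swap

This account rests on a few compounds, and the source may have more. Where it says the series, first, only, none or still open, it means among the compounds named here.

Two compounds of the series have been run in a functional assay on A549 cells (Homo sapiens) for cytotoxicity, read by MTT assay, with a stated time of 72 h; on this read-out lower numbers stand for stronger inhibition and higher numbers for weaker inhibition. Compound 1 `Cc1cc(=O)n(-c2ccc(F)cc2)nc1C(=O)Nc1ccc(Oc2ncnc3ccsc23)cc1` gives 2360 nM. Compound 2 `Cc1cc(=O)n(-c2ccccc2OC(F)(F)F)nc1C(=O)Nc1ccc(Oc2ncnc3ccsc23)c(F)c1` gives 5720 nM, the highest number of the two; its nearest neighbour is compound 1, and the gap between the two is beyond the usual scatter, so compound 2 is the weaker of the pair. Within the data shown here, no single-point step between measured compounds is available.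

Compound 3 `Cc1cc(=O)n(-c2ccc(F)cc2)nc1C(=O)Nc1ccc(Oc2ncnc3ccsc23)c(F)c1` is not yet measured. It differs from compound 2 by 4-fluorophenyl in place of 2-(trifluoromethoxy)phenyl on an aromatic nitrogen, leaving the rest of the shared core untouched. Compound 1, which also carries 4-fluorophenyl on that aromatic nitrogen, gives the lower number, so the change from compound 2 to compound 3 is expected to move this assay downward by a step of about a 2.3-fold lower number from compound 2 to compound 3 (0.36 log units; beyond the scatter). Compound 3 is therefore estimated at 2500 nM, with a range from 1000 nM to 6500 nM.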

Compound 3, half-maximal inhibitory concentration: 580 nM
The estimate for compound 3 lay 4.3-fold (0.63 log units) above the measured number, and the stated range ends above it.
By their numbers in this assay, from the lowest: compound 3; then compound 1; then compound 2.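

In this assay, among these compounds, 4-fluorophenyl in place of 2-(trifluoromethoxy)phenyl on the aromatic nitrogen gives a 9.9-fold lower number from compound 2 to compound 3 (0.99 log units; beyond the scatter) with the rest of the shared core held fixed, the first direct reading of the aryl group at this position. Fluoro in place of hydrogen on an aromatic carbon gives a 4.1-fold lower number from compound 1 to compound 3 (0.61 log units; beyond the scatter) with 4-fluorophenyl kept on the nitrogen, so this second site also moves the number beyond the scatter. The earlier gap between compound 1 and compound 2 therefore combined two changes running in opposite directions, the fluoro step downward and the move to 2-(trifluoromethoxy)phenyl upward.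

Still open, on these data alone, is how plain phenyl, 2-fluorophenyl or cyclohexyl on that nitrogen would read, and whether chloro or methyl could replace the fluoro. Nothing available explains either step.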